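Changing the Benzyl Halogen Pattern from Compound 3 to Compound 4

The source may report more compounds than this note shows. Statements on the series, on what has been measured and on what is new or still open speak of the compounds shown alone.

Of the compounds shown here, three built on one shared core have been measured in a functional assay on QGY7701 cells (Homo sapiens) for cytotoxicity, read by MTT assay, with a stated time of 48 h; a higher number here means a weaker inhibitor, a lower number a stronger inhibitor. Compound 1 `Cc1cccc(Cn2cc(COc3ccc4c(=O)ccoc4c3)nn2)c1` gives 22400 nM, compound 2 `Cc1ccc(Cn2cc(COc3ccc4c(=O)ccoc4c3)nn2)cc1` gives 68500 nM, and compound 3 `O=c1ccoc2cc(OCc3cn(Cc4cccc(Br)c4)nn3)ccc12` gives 17600 nM. Compound 3 holds the lowest number of the three, yet its gap to compound 1 lies within the scatter, so those two cannot be ordered; only compound 2 stands clearly apart, as a 3.9-fold lower number from compound 2 to compound 3 (0.59 log units; beyond the scatter) shows. The other steps are a 3.1-fold higher number from compound 1 to compound 2 (0.49 log units; beyond the scatter) and a 1.3-fold lower number from compound 1 to compound 3 (0.10 log units; within the scatter).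

Compound 4 `O=c1ccoc2cc(OCc3cn(Cc4ccc(Cl)cc4Cl)nn3)ccc12` differs from compound 3 in a single place: 2,4-dichlorophenyl in place of 3-bromophenyl on a saturated chain carbon bound to an aromatic nitrogen. The measured steps that bear on this are those that alter the substitution of the same phenyl ring, namely a 3.9-fold lower number from compound 2 to compound 3 (0.59 log units; beyond the scatter) and a 3.1-fold higher number from compound 1 to compound 2 (0.49 log units; beyond the scatter), both modest, together with a 1.3-fold lower number from compound 1 to compound 3 (0.10 log units; within the scatter), which stays within the scatter. Within the data shown here, no measured compound carries two chlorines on that ring, so the direction of the change is open. The step expected is a 1.1-fold higher number from compound 3 to compound 4 (0.06 log units; within the scatter), not beyond the scatter, with wide bounds. Compound 4 is expected to give 20000 nM in this assay, with an estimated range from 7000 nM to 60000 nM.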

Compound 4, half-maximal inhibitory concentration: 13300 nM
Beside the measured number, compound 4's estimate is 1.5-fold (0.18 log units) above it; measured number inside the range.
By their numbers in this assay, from the lowest: compounds 4, 3 and 1 (each within the scatter of the next); then compound 2.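

In this assay, among these compounds, the 2,4-dichlorophenyl group gives the first reading of a ring with two substituents at this position, on a saturated chain carbon bound to an aromatic nitrogen, and it cannot be told apart from 3-bromophenyl (a 1.3-fold lower number from compound 3 to compound 4 (0.12 log units; within the scatter)) or from 3-methylphenyl (a 1.7-fold lower number from compound 1 to compound 4 (0.23 log units; within the scatter)), since both steps stay within the scatter. Going from one substituent to two, and from bromo or methyl to chlorine, therefore brings no readable change against those two compounds, and 4-methylphenyl remains the only group that stands apart, now also against the dichlorinated ring (a 5.2-fold lower number from compound 2 to compound 4 (0.71 log units; beyond the scatter)). Nothing in the data on hand accounts for this outcome.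

The swap alters the halogen, the number of substituents and their ring places all at once, so the compounds shown leave open what each of these contributes, a question that 2-chlorophenyl and 4-chlorophenyl would separate. They also leave open how this position answers to a group of a different kind, such as an amine or a carboxylic acid on the ring, or a longer chain in place of the single saturated carbon.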